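A few compounds are considered here, and "the series" means these few. Any claim that something is new, unique, unknown or untested is made for them only; others in the source may bear on it.

Notes on the series in an ADME assay on HEK293 cells (Homo sapiens) for cytotoxicity, read by resazurin assay, with a stated time of 48 h; on this read-out lower numbers stand for higher toxicity in this test and higher numbers for lower toxicity in this test. Compound 1 `O=S(=O)(Nc1ccc(-c2nc3ccccc3o2)cc1)c1cccc(F)c1` reads > 100000 nM, which is a limit of the assay and not a number. Compound 2 `O=S(=O)(Nc1ccc2oc(-c3ccccc3)nc2c1)c1cccc(C(F)(F)F)c1` reads > 100000 nM, also a limit. Compound 1 thus sits at the limit of > 100000 nM in this assay, at which 2 of the 3 values shown sit. For the measured compounds named here, compound 3 `O=S(=O)(Nc1ccc(-c2nc3ccccc3o2)cc1)c1ccc(Cl)c(C(F)(F)F)c1` gives 69000 nM, the only full number so far. Compound 4 `Cc1ccc(S(=O)(=O)Nc2ccc(-c3nc4ccccc4o3)cc2)cc1` carries 4-methylphenyl in place of 3-fluorophenyl on a sulfonyl sulfur. Going by the values given here, no step between measured compounds is available to size this change, so none beyond the scatter is expected. The expected change is an at least 1.1-fold lower number from compound 1 to compound 4 (0.04 log units; that floor lies within the scatter). For compound 4 the estimated half-maximal cytotoxic concentration is 90000 nM, within an expected range of 50000 nM to 150000 nM.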

Compound 4, half-maximal cytotoxic concentration: 88000 nM
Compound 4: middle estimate off by 1.0-fold (0.01 log units), on the high side; the range from low to high includes it.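

In this assay, for the compounds shown here, 4-methylphenyl in place of 3-fluorophenyl on a sulfonyl sulfur gives the first step, an at least 1.1-fold lower number from compound 1 to compound 4 (0.05 log units; that floor lies within the scatter). From the compounds shown here alone, compound 1 is a limit and not a number, so this step is only a floor and its real size remains unknown: the limit of > 100000 nM in this assay, at which 2 of the 4 values shown sit. The swap thus gives no sign of a change beyond the scatter at this position.

Going by these compounds, what an amine or a carboxylic acid would read in place of 3-fluorophenyl on the sulfonyl sulfur stays open.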